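Swapping Methyl for Methoxy on Compound 2

The source may hold more compounds than are shown below. What is called first, only, known or untested is meant among the compounds shown, and "the series" means these compounds.

Values in a physicochemical assay for lipophilicity, measured as octanol-water partition; a lower number here means a more polar compound, a higher number a more lipophilic compound:
- compound 1 `O=C(NNc1ccnc2cc(Cl)ccc12)c1ccccc1/N=C/c1ccc(Cl)cc1Cl`: 6.22
- compound 2 `Cc1ccc(/C=N/c2ccccc2C(=O)NNc2ccnc3cc(Cl)ccc23)cc1`: 5.31

Going by the values given here, with only two compounds measured, compound 2 at 5.31 holds the lower of the two numbers, and compound 1 holds the higher at 6.22.

The next structure, compound 3 `COc1ccc(/C=N/c2ccccc2C(=O)NNc2ccnc3cc(Cl)ccc23)cc1`, keeps everything in compound 2 except one group: methoxy in place of methyl on an aromatic carbon. The rest of the molecule stays the same, so any shift in this assay can be traced to this single swap.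

Among the compounds with values here, only one measured step bears on it, and that step is a different swap on the same aryl group: a number 0.91 log units lower from compound 1 to compound 2 (beyond the scatter). It replaced a 2,4-dichlorophenyl group, so it says little about this smaller change from 4-methylphenyl to 4-methoxyphenyl. Within the data shown here, no measured pair tests the swap directly, which leaves the estimate loose. A smaller step than that one is expected, pointing downward.

The estimated change is a number 0.41 log units lower from compound 2 to compound 3 (beyond the scatter). Compound 3 is expected at 4.9, with an estimated range from 4.4 to 5.4.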

Compound 3, partition coefficient: 5
Compound 3: the middle estimate sits 0.10 log units below what was measured, and the stated range covers the measured number.
By their numbers in this assay, from the lowest: compound 3; then compound 2; then compound 1.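

In this assay, the change from 4-methylphenyl to 4-methoxyphenyl now has a measured size of its own: a number 0.31 log units lower from compound 2 to compound 3 (beyond the scatter). So a small swap on an aromatic carbon, para to a large group, that adds an oxygen to the substituent moves the number beyond the usual scatter, although by less than the replacement of the whole 2,4-dichlorophenyl group, which reads a number 1.22 log units lower from compound 1 to compound 3 (beyond the scatter) with the methoxy compound. Nothing available here explains why the number moves in this direction or by this amount.

The compounds shown cover only methyl and methoxy at this position, alongside the 2,4-dichlorophenyl group, so two neighbouring values cannot establish a trend. A hydroxyl, an amine or a carboxylic acid at the same place, or a longer chain such as ethoxy, would show whether the number keeps falling or rises again, and an unsubstituted phenyl would give a plain reference point for all of these swaps.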